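Glucoside series on oral squamous cells: methyl on a phenol oxygen

This account rests on a few compounds, and the source may have more. Where it says the series, first, only, none or still open, it means among the compounds named here.

Of the compounds shown here, three have been measured in a functional assay on HSC-2 cells (Homo sapiens) for cytotoxicity, read by MTT assay; a higher number here means a weaker inhibitor, a lower number a stronger inhibitor. The aglycone compound 1 `Oc1ccc(CC[C@@H](O)C[C@H](O)CCc2ccc(O)c(O)c2)cc1O` gives 54 ug/mL. The glucoside compound 2 `OC[C@H]1O[C@@H](O[C@H](CCc2ccc(O)c(O)c2)C[C@H](O)CCc2ccc(O)cc2)[C@H](O)[C@@H](O)[C@@H]1O` gives 158 ug/mL, the highest of the three numbers; compound 3 `OC[C@H]1O[C@@H](O[C@H](CCc2ccc(O)cc2)C[C@H](O)CCc2ccc(O)c(O)c2)[C@H](O)[C@@H](O)[C@@H]1O` gives 155 ug/mL, which sits within the scatter of the value for compound 2, so the two cannot be ordered. Compound 1 lies beyond the scatter below compound 2, the widest gap in the set.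

The next compound, compound 4 `COc1cc(CC[C@H](C[C@H](O)CCc2ccc(O)cc2)O[C@@H]2O[C@H](CO)[C@@H](O)[C@H](O)[C@H]2O)ccc1O`, differs from compound 2 in one place: methyl in place of hydrogen on an oxygen on an aromatic ring. Among the measured compounds shown here, no pair of measured compounds differs by this change, so its effect in this assay is not known from the data at hand. Compound 4 is expected to stay close to compound 2, with a step of a 1.1-fold higher number from compound 2 to compound 4 (0.04 log units; within the scatter) that lies within the scatter, and if anything a slightly higher number. The estimate for compound 4 is 175 ug/mL, with a range from 90 ug/mL to 330 ug/mL.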

Compound 4, half-maximal inhibitory concentration: 160 ug/mL
For compound 4 the middle estimate is 1.1-fold (0.04 log units) above the measured one; low and high end bracket the measured number.
By their numbers in this assay, from the lowest: compound 1; then compounds 3, 2 and 4 (each within the scatter of the next).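

In this assay, among the compounds shown here, replacing 3,4-dihydroxyphenyl with 4-hydroxy-3-methoxyphenyl on the glucoside gives a 1.0-fold higher number from compound 2 to compound 4 (0.01 log units; within the scatter), the first reading of methyl in place of hydrogen on an oxygen on an aromatic ring. At this position, then, the free hydroxy can be exchanged for methoxy with no change that can be told from the scatter, though this rests on a single pair and says nothing about other positions. Nothing at hand bears on why the number holds.

Still open, going by these compounds, is whether a larger group on the same oxygen, such as ethyl or benzyl, would also leave the number in place. The compounds shown also leave open whether the same methyl step would read alike on the aglycone compound 1, which carries no glucose.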